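Swapping iodine for bromine on the carbamate aryl ring

This account rests on a few compounds, and the source may have more. Where it says the series, first, only, none or still open, it means among the compounds named here.

Measured so far in a functional assay on RAW264.7 cells (Mus musculus) for inhibition, with a stated time of 30 min; a higher number here means a weaker inhibitor, a lower number a stronger inhibitor:
compound 1 `C=C1C(=O)OC[C@H]1CCOC(=O)Nc1ccc(I)cc1`: 490 nM
compound 2 `C=C1C(=O)OC[C@@H]1CCOC(=O)Nc1ccc(I)cc1`: 790 nM
compound 3 `C=C1C(=O)OC[C@@H]1CCOC(=O)Nc1cccc(Br)c1`: 840 nM

Compound 2 gives the second highest of the three numbers in this assay; its value sits close to that of compound 3, and the step of a 1.6-fold higher number from compound 1 to compound 2 (0.21 log units; within the scatter) is within the scatter, a step that rests only on the drawn configuration (the fact that compounds 1 and 2 differ only in the configuration as drawn). Compound 4 `C=C1C(=O)OC[C@@H]1CCOC(=O)Nc1ccc(Br)cc1` differs from compound 2 by bromo in place of iodo on an aromatic carbon. For the measured compounds named here, no measured step exchanges one halogen for another, so nothing in this assay bears directly on the change; the values of compound 2 and compound 3 show that two halogen-bearing aryl groups land close together. The expected step of a 1.1-fold higher number from compound 2 to compound 4 (0.06 log units; within the scatter) is therefore none beyond the scatter. Compound 4 is estimated at 900 nM, within 450 nM to 1800 nM.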

Compound 4, half-maximal inhibitory concentration: 720 nM
Compound 4: the middle estimate sits 1.3-fold (0.10 log units) above what was measured; low and high end bracket the measured number.
By their numbers in this assay, from the lowest: compounds 1, 4, 2 and 3 (each within the scatter of the next).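

In this assay, for the compounds shown here, the first direct exchange of one halogen for another, bromo in place of iodo on an aromatic carbon para to a large group, gives a 1.1-fold lower number from compound 2 to compound 4 (0.04 log units; within the scatter). At this place on the ring, then, the two halogens cannot be told apart in this read-out. Nothing available here bears on why the two compounds match so closely. Still open, as far as these compounds go, is whether a much different group at this place, such as an amine, a methoxy group or a carboxylic acid, would shift the number beyond the scatter.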